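Aryl-amino variation on the shared core: step to compound 4

The source may report more compounds than this note shows. Statements on the series, on what has been measured and on what is new or still open speak of the compounds shown alone.

Compound 1 `Clc1ccc(Nc2nnc(COc3ccc(-c4ccccc4)cc3)s2)cc1` gives 52.3% in a functional assay on the whole organism (strain Wistar) for inhibition, with Rattus norvegicus as the target, read by paw edema, with a stated time of 3 h, at a dose of 10 mg/kg by the oral route; on this read-out higher numbers stand for more inhibition at the one dose given (going by the name of the read-out) and lower numbers for less inhibition. Compound 2 `Brc1ccc(Nc2nnc(COc3ccc(-c4ccccc4)cc3)s2)cc1` gives 63.6%; the step of a number 11.3 percentage points higher from compound 1 to compound 2 (beyond the scatter). Compound 3 `Fc1ccc(Nc2nnc(COc3ccc(-c4ccccc4)cc3)s2)cc1` gives 27.3%, the lowest of the three numbers; the steps of a number 25 percentage points lower from compound 1 to compound 3 (beyond the scatter) and a number 36.3 percentage points lower from compound 2 to compound 3 (beyond the scatter) both run downward. Compound 4 `Cc1ccccc1Nc1nnc(COc2ccc(-c3ccccc3)cc2)s1` differs from compound 3 by 2-methylphenyl in place of 4-fluorophenyl on a nitrogen on an aromatic ring. Among the measured compounds shown here, no measured step exchanges a halogen for a methyl or changes where the substituent sits, so none bears directly; the three halogen swaps only show that changes at this position move the read-out by modest to large amounts in either direction. Compound 4 is therefore expected to land somewhere inside the span of the three measured values, estimated at 42% with a range of 18% to 66%; the step of a number 14.7 percentage points higher from compound 3 to compound 4 (beyond the scatter) is expected upward but with little confidence.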

Compound 4, a percentage reported as inhibition, in the whole organism at one dose (the size of the read-out at that dose, not a potency): 25%
The estimate for compound 4 lay 17 percentage points above the measured number; the range from low to high includes it.
By their numbers in this assay, from the lowest: compounds 4 and 3 (each within the scatter of the next); then compound 1; then compound 2.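

The change from 4-fluorophenyl to 2-methylphenyl on the nitrogen does not separate the two compounds, with a number 2.3 percentage points lower from compound 3 to compound 4 (within the scatter). A group without halogen therefore reads like the fluoro compound and stays well short of the other two, with a number 38.6 percentage points lower from compound 2 to compound 4 (beyond the scatter) and a number 27.3 percentage points lower from compound 1 to compound 4 (beyond the scatter). No available evidence accounts for these steps.

Since both the group and its place on the phenyl ring change, the two contributions cannot be separated. On these data alone, how a 4-methylphenyl, 4-methoxyphenyl or 4-aminophenyl group would read at this position remains open.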